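A few compounds are considered here, and "the series" means these few. Any claim that something is new, unique, unknown or untested is made for them only; others in the source may bear on it.

Compound 2, drawn as `COc1cc(/C=C/C(=O)/C=C(O)/C=C/c2ccc(OC(=O)[C@H](CCSC)NC(=O)OC(C)(C)C)c(OC)c2)ccc1OC(=O)[C@H](CCSC)NC(=O)OC(C)(C)C`, was tested in a functional assay on the whole organism (strain Wistar) for inhibition, with Rattus norvegicus as the target, read by paw edema, with stated times of 1 h and 2 h, at a dose of 10 mg/kg by the intraperitoneal route (a lower number here means less inhibition, a higher number more inhibition at the dose given (going by the name of the read-out)), and gave 36%. Compound 1, drawn as `COc1cc(/C=C/C(=O)/C=C(O)/C=C/c2ccc(OC(=O)[C@@H](C)NC(=O)OC(C)(C)C)c(OC)c2)ccc1OC(=O)[C@@H](C)NC(=O)OC(C)(C)C`, gave 29% in this assay; the two numbers lie within the scatter of each other, so the inhibition in this assay is level between them. Compound 3, drawn as `COc1cc(/C=C/C(=O)/C=C(O)/C=C/c2ccc(OC(=O)[C@@H](CCSC)NC(=O)OC(C)(C)C)c(OC)c2)ccc1OC(=O)[C@@H](CCSC)NC(=O)OC(C)(C)C`, relates to compound 2 as follows: the two compounds have the same atoms and bonds and differ only in configuration as drawn: 2 of 5 stereo elements differ; a stereocentre at a saturated chain carbon is drawn S in compound 2 and R in compound 3; a stereocentre at a saturated chain carbon is drawn S in compound 2 and R in compound 3. Within the data shown here, no step between two measured compounds shows what such a change in configuration does. With compound 2 as the only anchor, the step of a number 3 percentage points lower from compound 2 to compound 3 (within the scatter) is expected to stay within the scatter. Compound 3 is therefore expected to give about 33% in this assay, between 20% and 46%.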

Compound 3, a percentage reported as inhibition, in the whole organism at one dose (the size of the read-out at that dose, not a potency): 69%
Compound 3: middle estimate off by 36 percentage points, on the low side; the measured number lies above the stated range.
By their numbers in this assay, from the lowest: compounds 1 and 2 (each within the scatter of the next); then compound 3.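

In this assay the two stereocentres on the saturated chains matter: drawing both R instead of S gives a number 33 percentage points higher from compound 2 to compound 3 (beyond the scatter) at the same dose. The earlier pair differed in its side chains and stayed level, so it showed nothing about configuration alone. This change can be tied to configuration because nothing else separates the two compounds: the fact that compounds 2 and 3 differ only in the configuration as drawn

From the compounds shown here alone, both centres change together, so the share of each remains open. Also open, going by these compounds, is whether the same inversion would matter in compound 1, or with a free amine in place of the tert-butyl carbamate.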